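Cyclohexyl to 4-fluorophenyl on the ring nitrogen

The source may report more compounds than this note shows. Statements on the series, on what has been measured and on what is new or still open speak of the compounds shown alone.

Of the compounds shown here, two sharing one core have been measured in a functional assay on HepG2 cells (Homo sapiens) for antiproliferative activity, read by MTT assay, with a stated time of 72 h; a higher number here means a weaker inhibitor, a lower number a stronger inhibitor. Compound 1 `COc1cccc(N2C(=O)COc3ccc(-c4cccc(NS(=O)(=O)c5ccc(F)cc5)c4)cc32)c1` gives > 40000 nM, which is a limit of the assay and not a number. Among the measured compounds shown here, compound 2 `O=C1COc2ccc(-c3cccc(NS(=O)(=O)c4ccc(F)cc4)c3)cc2N1C1CCCCC1` gives 35900 nM, the only actual number so far, and it stands alongside (the limit of > 40000 nM in this assay, at which 1 of the 2 values shown sits).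

Compound 3 `O=C1COc2ccc(-c3cccc(NS(=O)(=O)c4ccc(F)cc4)c3)cc2N1c1ccc(F)cc1` has 4-fluorophenyl in place of cyclohexyl on an amide-type nitrogen in a ring, (4-fluorophenyl in place of cyclohexyl on an amide-type nitrogen in a ring). For the measured compounds named here, the one measured step at this nitrogen, an at least 1.1-fold lower number from compound 1 to compound 2 (0.04 log units; that floor lies within the scatter), puts cyclohexyl in place of 3-methoxyphenyl and stays within the scatter. Compound 3 returns an aromatic ring to that nitrogen, so it is expected to show no step beyond the scatter in this assay, and it may well report only a limit. The expected change is a 1.0-fold lower number from compound 2 to compound 3 (0.01 log units; within the scatter). For compound 3 the estimated value is 35000 nM, with an expected range of 17000 nM to 70000 nM.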

Compound 3, half-maximal inhibitory concentration: > 40000 nM
Compound 3 ended at the assay's limit; the forecaster's own chance of this, stated with the estimate: 50%; middle value at least 1.1-fold (0.05 log units) from the limit.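

Going from cyclohexyl to 4-fluorophenyl on the amide-type nitrogen in a ring gives an at least 1.1-fold higher number from compound 2 to compound 3 (0.04 log units; that floor lies within the scatter) in this assay, so this change, like the earlier one from 3-methoxyphenyl to cyclohexyl, shows no step beyond the scatter. The step between compound 1 and compound 3 cannot be read, as both values are limits. With a second aromatic ring tested on this nitrogen, the picture at this position now rests mostly on a limit and not on numbers: the limit of > 40000 nM in this assay, at which 2 of the 3 values shown sit.

Going by these compounds, whether a methyl group, a longer alkyl chain, or a chain ending in an amine or a carboxylic acid on this nitrogen would give a number clearly lower than that of compound 2 stays open. So does whether a change elsewhere on the shared core would do so.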